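Trading fluoro for trifluoromethyl in compound 4

The source may hold more compounds than are shown below. What is called first, only, known or untested is meant among the compounds shown, and "the series" means these compounds.

Values in a functional assay on MCF7 cells (Homo sapiens) for antiproliferative activity, read by CellTiter-Glo, with a stated time of 5 days; a higher number here means a weaker inhibitor, a lower number a stronger inhibitor:
Compound 1 `O=C(O)/C=C/c1ccc(/C(=C(\c2ccc(C(F)(F)F)cc2Cl)C2CCC2)c2ccc3nccn3c2)cc1`: 5.1 nM
Compound 2 `O=C(O)/C=C/c1ccc(/C(=C(\c2ccccc2)C2CCC2)c2ccc(-c3cn[nH]c3)cc2)cc1`: 11 nM
Compound 3 `O=C(O)/C=C/c1ccc(/C(=C(\c2ccc(F)cc2Cl)C2CCC2)c2ccc(-c3cn[nH]c3)cc2)cc1`: 2.9 nM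

Compound 3, at 2.9 nM, cannot be told apart from compound 1, at 5.1 nM. Compound 2, at 11 nM, gives a clearly larger number than compound 3. The next molecule, compound 4 `O=C(O)/C=C/c1ccc(/C(=C(\c2ccc(C(F)(F)F)cc2Cl)C2CCC2)c2ccc(-c3cn[nH]c3)cc2)cc1`, carries trifluoromethyl in place of fluoro on an aromatic carbon. Among the compounds with values here, no measured step makes this exact change. The closest evidence is a 3.8-fold lower number from compound 2 to compound 3 (0.58 log units; beyond the scatter), a modest gain seen when 2-chloro-4-fluorophenyl replaced phenyl. Compound 1 already carries 2-chloro-4-(trifluoromethyl)phenyl, and although the rest of its structure differs, its value of 5.1 nM shows that this group can occur with a low number. No shift beyond the scatter is therefore expected in this assay, and the estimated change is a 1.2-fold higher number from compound 3 to compound 4 (0.08 log units; within the scatter). The estimate for compound 4 is 3.5 nM, with an expected range from 1.4 nM to 9 nM.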

Compound 4, half-maximal inhibitory concentration: 16 nM
Estimate against measurement, compound 4: 4.6-fold (0.66 log units) below; the whole stated range lies below it.
By their numbers in this assay, from the lowest: compounds 3 and 1 (each within the scatter of the next); then compounds 2 and 4 (each within the scatter of the next).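

In this assay, the position para to the large group proves sensitive: with the chloro group kept, the change from fluoro to trifluoromethyl gives a 5.5-fold higher number from compound 3 to compound 4 (0.74 log units; beyond the scatter) and so is not a neutral swap. With trifluoromethyl in this place, the ring that carries it no longer stands clearly apart from the plain phenyl ring, at a 1.5-fold higher number from compound 2 to compound 4 (0.16 log units; within the scatter) and against the earlier 3.8-fold lower number from compound 2 to compound 3 (0.58 log units; beyond the scatter) seen with fluoro. With 2-chloro-4-(trifluoromethyl)phenyl held constant, the other group on the double bond also counts, as a 3.1-fold higher number from compound 1 to compound 4 (0.50 log units; beyond the scatter) shows.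

No measurement shown here explains the rise at this position. Still open, on these data alone, is how a methyl or a nitrile would read in this place, and whether fluoro on the core of compound 1 would give a step of similar size.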